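This account rests on a few compounds, and the source may have more. Where it says the series, first, only, none or still open, it means among the compounds named here.

Compounds tested in an ADME assay on Vero cells (Chlorocebus sabaeus) for cytotoxicity, read by MTT assay, with a stated time of 72 h; a lower number here means that less compound is tolerated, a higher number that more compound is tolerated:

- compound 1 `CC(C)=CCCC1(C)C=Cc2c(ccc(C(=O)/C=C/c3cccnc3)c2O)O1`: 40700 nM
- compound 2 `COc1ccc(/C=C/C(=O)c2ccc3c(c2O)C=CC(C)(CCCC(C)C)O3)cc1`: "not determined" (no result reported)
- compound 3 `CC(C)CCCC1(C)C=Cc2c(ccc(C(=O)/C=C/c3ccc(O)cc3)c2O)O1`: "not determined" (no result reported)

Only compound 1 has a number in this small set. Compound 3 has no position on the scale: for compound 3 the entry reads "not determined" (no result reported), so it cannot be called better or worse tolerated than anything else here. Compound 2 is in the same situation, with "not determined" (no result reported) as its entry.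

The next compound, compound 4 `CC(C)CCCC1(C)C=Cc2c(ccc(C(=O)/C=C/c3cccnc3)c2O)O1`, comes from compound 3 by one structural change: pyridin-3-yl in place of 4-hydroxyphenyl on a double-bonded chain carbon bound to a double-bonded chain carbon. The swap takes place on a double-bonded chain carbon bound to a double-bonded chain carbon, and the rest of the molecule stays as it was.

Within the data shown here, no measured pair in this set shows what such a swap does in this assay, so the size of the step cannot be read from the data. Among the measured compounds shown here, the working expectation is therefore cautious: no shift in either direction beyond the usual scatter, with compound 4 expected to fall in the region of the one available number, where compound 1 gives 40700 nM. That anchor is a single measurement, so the range is kept wide.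

For compound 4 the estimated half-maximal cytotoxic concentration is 40000 nM, with an expected range of 15000 nM to 100000 nM.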

Compound 4, half-maximal cytotoxic concentration: 156000 nM
The estimate for compound 4 lay 3.9-fold (0.59 log units) below the measured number, and the stated range ends below it.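

Compound 3 has no number, so the size of the swap from 4-hydroxyphenyl to pyridin-3-yl cannot be read. In this assay, among these compounds, the one readable step is a 3.8-fold higher number from compound 1 to compound 4 (0.58 log units; beyond the scatter) and it goes with a change elsewhere in the molecule: isobutyl in place of 2-methylprop-1-en-1-yl on a saturated chain carbon, two bonds along the chain from a saturated ring carbon, with the pyridin-3-yl group kept, so this chain end matters in this pair, with more of compound 4 tolerated, by a margin beyond the usual scatter. Nothing measured here explains why this change moves the number.

The compounds shown leave open whether the same chain change would give a step of similar size with 4-hydroxyphenyl or 4-methoxyphenyl in place of pyridin-3-yl. They also leave open what a longer chain, or an amine or a carboxylic acid at the end of the chain, would do at this position.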